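A few compounds are considered here, and "the series" means these few. Any claim that something is new, unique, unknown or untested is made for them only; others in the source may bear on it.

Measured compounds:
compound 1 `CN(C(=O)C(C)(C)C)c1ccc2[nH]c(-c3n[nH]c4ccccc34)cc2n1`: 22200 nM
compound 2 `CN(C(=O)c1ccc(F)cc1)c1ccc2[nH]c(-c3n[nH]c4ccccc34)cc2n1`: 9150 nM
compound 3 `CN(C(=O)c1ccc(Br)cc1)c1ccc2[nH]c(-c3n[nH]c4ccccc34)cc2n1`: 3460 nM

All three share one core and differ only in the group on the carbonyl carbon of the amide. In a functional assay on SMMC-7721 cells (Homo sapiens) for antiproliferative activity, read by MTT assay, with a stated time of 72 h (on this read-out higher numbers stand for weaker inhibition and lower numbers for stronger inhibition), compound 3 gives the lowest of the three numbers: a 6.4-fold lower number from compound 1 to compound 3 (0.81 log units; beyond the scatter) and a 2.6-fold lower number from compound 2 to compound 3 (0.42 log units; beyond the scatter), both beyond the scatter, while a 2.4-fold lower number from compound 1 to compound 2 (0.38 log units; beyond the scatter) is the smaller of the two measured moves away from compound 1.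

Compound 4 `CN(c1ccc2[nH]c(-c3n[nH]c4ccccc34)cc2n1)S(=O)(=O)c1ccc(Br)cc1` is the next step from compound 3: (4-bromophenyl)sulfonyl in place of (4-bromophenyl)carbonyl on a nitrogen on an aromatic ring. The amide is thereby replaced by a sulfonamide, with the 4-bromophenyl ring retained.

Among the compounds with values here, none of the measured steps bears on this change: every one of them varies the group on the carbonyl carbon and keeps the carbonyl itself, so there is no measured pair that exchanges a carbonyl for a sulfonyl. Without such a precedent, no step beyond the scatter in this assay is expected in either direction, and the estimate for compound 4 is set near compound 3 with a wide range, as a 1.2-fold higher number from compound 3 to compound 4 (0.06 log units; within the scatter). Compound 4 is therefore expected to give about 4000 nM, within 1200 nM to 15000 nM.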

Compound 4, half-maximal inhibitory concentration: 11500 nM
For compound 4 the middle estimate is 2.9-fold (0.46 log units) below the measured one, and the stated range covers the measured number.
By their numbers in this assay, from the lowest: compound 3; then compounds 2, 4 and 1 (each within the scatter of the next, the first and the last beyond it).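

In this assay, exchanging the carbonyl for a sulfonyl on this nitrogen, with the 4-bromophenyl ring kept, gives a 3.3-fold higher number from compound 3 to compound 4 (0.52 log units; beyond the scatter), so the linking group affects the read-out as well as the group it carries. The sulfonamide is not separated from either of the other amides, with a 1.3-fold higher number from compound 2 to compound 4 (0.10 log units; within the scatter) and a 1.9-fold lower number from compound 1 to compound 4 (0.29 log units; within the scatter), so the advantage seen for the 4-bromophenyl amide does not carry over to the sulfonamide in this set. No measurement available here explains the effect of the exchange.

As far as these compounds go, it remains open whether the same exchange has a similar effect with 4-fluorophenyl or tert-butyl on the sulfonyl. Also open, from the compounds shown here alone, is how a urea, a carbamate or a simple amine linkage at this nitrogen would compare.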